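Adding a Methyl Group to the Most Potent Compound

The compounds below may be only part of what the source reports. "The series", "measured", "known", "first", "only" and "open" are said of these compounds alone.

Among the three compounds measured in a functional assay on Bel-7402 cells (Homo sapiens) for cytotoxicity, read by MTT assay, with a stated time of 48 h (a lower number here means a stronger inhibitor, a higher number a weaker inhibitor), compound 3 `CCn1cc(-c2nc3ccc([N+](=O)[O-])cc3s2)c(=O)c2cc(F)c(N3CCNCC3)cc21` stands lowest: compound 3 gives 1800 nM, while compound 1 `CCn1cc(-c2nc3ccccc3s2)c(=O)c2cc(F)c(N3CCNCC3)cc21` gives 24300 nM and compound 2 `CCn1cc(-c2nc3ccccc3s2)c(=O)c2cc(F)c(N3CCN(C)CC3)cc21` gives 24000 nM. Both of those separations are beyond the scatter, and the step that reaches compound 3 is a large one, a 14-fold lower number from compound 1 to compound 3 (1.13 log units; beyond the scatter), with nitro in place of hydrogen on an aromatic carbon.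

Compound 4 `CCn1cc(-c2nc3ccc([N+](=O)[O-])cc3s2)c(=O)c2cc(F)c(N3CCN(C)CC3)cc21` differs from compound 3 in a single place: methyl in place of hydrogen on an amine nitrogen in a ring. Cut one bond further out, the same difference reads piperazin-1-yl to 4-methylpiperazin-1-yl.

Exactly this change has been measured once already, between compound 1 and compound 2, where it gave a 1.0-fold lower number from compound 1 to compound 2 (0.01 log units; within the scatter). On that basis no step beyond the scatter is expected here in this assay. Compound 4 is therefore estimated to give 1800 nM, in a range from 800 nM to 4000 nM. That estimate means an expected step of no change at the digits printed from compound 3 to compound 4 (within the scatter), essentially none.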

Compound 4, half-maximal inhibitory concentration: 7700 nM
Estimate against measurement, compound 4: 4.3-fold (0.63 log units) below; measured number above the stated range.
By their numbers in this assay, from the lowest: compound 3; then compound 4; then compounds 2 and 1 (each within the scatter of the next).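

In this assay, the change from piperazin-1-yl to 4-methylpiperazin-1-yl does not behave the same way on every core: with the nitro group present it gives a 4.3-fold higher number from compound 3 to compound 4 (0.63 log units; beyond the scatter), so a methyl on this ring nitrogen matters on one core and not on the other: the same change on two cores in this assay, a 1.0-fold lower number (0.01 log units; within the scatter) from compound 1 to compound 2 and a 4.3-fold higher number (0.63 log units; beyond the scatter) from compound 3 to compound 4, 4.3-fold (0.64 log units) apart, beyond the scatter of two such steps. The nitro group still helps once the methyl is in place, giving a 3.1-fold lower number from compound 2 to compound 4 (0.49 log units; beyond the scatter), but this step is smaller than the one seen with the hydrogen on that nitrogen: the same change on two cores in this assay, a 14-fold lower number (1.13 log units; beyond the scatter) from compound 1 to compound 3 and a 3.1-fold lower number (0.49 log units; beyond the scatter) from compound 2 to compound 4, 4.3-fold (0.64 log units) apart, beyond the scatter of two such steps. Across these four compounds, then, the two changes do not add independently, since the size of each depends on the other.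

Going by these compounds, whether the same dependence holds for an ethyl or acetyl group on that ring nitrogen, or for an amine or a nitrile in place of the nitro group, remains open. These four compounds, all read in this assay, do not tell what lies behind the dependence.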